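Acid dissociation notes: from compound 1 to compound 4

The source may hold more compounds than are shown below. What is called first, only, known or untested is meant among the compounds shown, and "the series" means these compounds.

Of the compounds shown here, three have been read in a physicochemical assay for acid dissociation, read by spectrophotometry. Compound 1 `CCc1c(O)c(=O)ccn1CCCn1ccnc1` gives 3.15 and stands highest of the three, beyond the scatter of both others. Compound 2 `CCN(CC)CCn1ccc(=O)c(O)c1C` gives 2.66 in this assay, and compound 3 `Cc1cc(=O)c(O)c(CN2CCCCC2)n1C` gives 2.73. No pair among these three differs in one place only, so no single step is isolated.

Compound 4 `CCc1c(O)c(=O)ccn1CCN1CCCCC1` awaits this assay. It differs from compound 1 as follows: piperidin-1-yl in place of (1H-imidazol-1-yl)methyl on a saturated chain carbon, two bonds along the chain from an aromatic nitrogen. The step from compound 1 to compound 4 is expected to be a drop of moderate size, a number 0.40 log units lower from compound 1 to compound 4 (beyond the scatter), since compound 2 at 2.66 and compound 3 at 2.73 both sit lower than compound 1. Compound 4 is estimated at 2.75, with a range from 2.35 to 3.15.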

Compound 4, acid dissociation constant: 2.74
Estimate against measurement, compound 4: 0.01 log units above; the measured number falls inside the stated range.
By their numbers in this assay, from the lowest: compounds 2, 3 and 4 (each within the scatter of the next); then compound 1.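

In this assay, the series now has one isolated step: piperidin-1-yl in place of (1H-imidazol-1-yl)methyl on a saturated chain carbon, two bonds along the chain from an aromatic nitrogen, gives a number 0.41 log units lower from compound 1 to compound 4 (beyond the scatter) on an otherwise unchanged structure. The read-out therefore responds to this change on the chain, with the shared core the same in both compounds. No supporting measurement bears on the origin of this step.

From the compounds shown here alone, whether a morpholine or a carboxylic acid in this place would move the number stays open. So does the outcome with a longer chain carrying piperidin-1-yl.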